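Three sulfonyl variants on one shared core, all at the limit

The source may report more compounds than this note shows. Statements on the series, on what has been measured and on what is new or still open speak of the compounds shown alone.

Compound 1 `CC(C)c1noc(N2CCN(C(=O)[C@@H]3CCCN(S(=O)(=O)c4ccc(S(=O)(=O)NC5CC5)cc4)C3)CC2)n1` gives > 10000 nM in a functional assay on MIA PaCa-2 cells (Homo sapiens) for inhibition, read by MTT assay, with a stated time of 3 days (a higher number here means a weaker inhibitor, a lower number a stronger inhibitor), a limit of the assay.
Compound 2 `CC(C)c1noc(N2CCN(C(=O)[C@@H]3CCCN(S(=O)(=O)c4ccc(S(=O)(=O)NC(C)(C)C)cc4)C3)CC2)n1` gives > 10000 nM in this assay, again a limit.
Compound 3 `CC(C)c1noc(N2CCN(C(=O)[C@@H]3CCCN(S(=O)(=O)c4ccc(S(=O)(=O)C(C)C)cc4)C3)CC2)n1` gives > 10000 nM in this assay, also a limit.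

Compound 3 therefore stands at the ceiling of what this assay reports, alongside the other two: the limit of > 10000 nM in this assay, at which 3 of the 3 values shown sit. Compound 4 `CC(C)NS(=O)(=O)c1ccc(S(=O)(=O)N2CCC[C@@H](C(=O)N3CCN(c4nc(C(C)C)no4)CC3)C2)cc1` differs from compound 3 by one change, (isopropylamino in place of isopropyl on a sulfonyl sulfur). Within the data shown here, the steps that bear on it, a step that the two limits leave unreadable from compound 1 to compound 3 and a step that the two limits leave unreadable from compound 2 to compound 3, both join two limits, so their size cannot be read, and the remaining step that the two limits leave unreadable from compound 1 to compound 2 is likewise unreadable. Among the measured compounds shown here, no measured step points to a gain, so compound 4 is expected to stay near the limit, an estimated step that the limit leaves unreadable from compound 3 to compound 4, giving a value of about 15000 nM within 5000 nM to 50000 nM.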

Compound 4, half-maximal inhibitory concentration: > 10000 nM
Compound 4: a limit, no number; the forecaster's own chance of this, stated with the estimate: 80%; the middle value is on the limit's open side.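

Among these compounds, compound 4 is also a limit, so no step among compound 1, compound 2, compound 3 and compound 4 can be read: the limit of > 10000 nM in this assay, at which 4 of the 4 values shown sit. In this assay the compounds shown leave open which sulfonyl group, if any, would give a measured number.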